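From 2-(diethylamino)ethyl to 3-(diethylamino)propyl at the limit

The source may report more compounds than this note shows. Statements on the series, on what has been measured and on what is new or still open speak of the compounds shown alone.

Measured in a functional assay on A549 cells (Homo sapiens) for antiproliferative activity, read by MTT assay, with a stated time of 48 h; a lower number here means a stronger inhibitor, a higher number a weaker inhibitor:
compound 1 `CN(C)CCn1c(N)c(-c2nc3ccccc3n2C)c2nc(C#N)c(C#N)nc21`: > 50000 nM, a limit
compound 2 `CCN(CC)CCn1c(N)c(-c2nc3ccccc3n2C)c2nc(C#N)c(C#N)nc21`: > 50000 nM, a limit

Compound 2 stands only at a limit, > 50000 nM, and has no numerical value. All the data so far sit at one point: the limit of > 50000 nM in this assay, at which 2 of the 2 values shown sit.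

Compound 3 `CCN(CC)CCCn1c(N)c(-c2nc3ccccc3n2C)c2nc(C#N)c(C#N)nc21` carries 3-(diethylamino)propyl on the shared core where compound 2 carries 2-(diethylamino)ethyl: (diethylamino)methyl in place of diethylamino on a saturated chain carbon, two bonds along the chain from an aromatic nitrogen.

Among the measured compounds shown here, the only measured step, a step that the two limits leave unreadable from compound 1 to compound 2, changes the groups on the amine and not the chain, and it gives no size to carry over. No step beyond the scatter is therefore expected in this assay, and a further limit is the likeliest report. The expected step is a number no higher from compound 2 to compound 3 (the limit leaves the size open). For compound 3 the estimate is 50000 nM, with an expected range of 25000 nM to 100000 nM.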

Compound 3, half-maximal inhibitory concentration: 10700 nM
Estimate against measurement, compound 3: 4.7-fold (0.67 log units) above; measured number outside the range, below it.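

In this assay, the change from 2-(diethylamino)ethyl to 3-(diethylamino)propyl gives an at least 4.6-fold lower number from compound 2 to compound 3 (0.66 log units; beyond the scatter). Taking dimethylamino on the shorter chain as the starting point gives an at least 4.6-fold lower number from compound 1 to compound 3 (0.66 log units; beyond the scatter), a comparison in which the amine groups and the chain both differ. The chain on the aromatic nitrogen therefore responds to this change, which the unreadable step between the two earlier compounds could not show, and only compound 3 carries a number: the limit of > 50000 nM in this assay, at which 2 of the 3 values shown sit.

As far as these compounds go, both readable steps start from a limit, so their full size stays open. Also open, from the compounds shown here alone, is whether a longer chain extends the trend, and whether dimethylamino, or a cyclic amine such as piperidine or morpholine, at the end of the propyl chain gives a similar number.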